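This account rests on a few compounds, and the source may have more. Where it says the series, first, only, none or still open, it means among the compounds named here.

Measured so far:
Compound 1, `NCc1ccc(C(=O)Nc2ccncc2F)cc1-c1cccc(C(=O)Oc2ccccc2)c1`: 6.2 nM
Compound 2, `NCc1ccc(C(=O)Nc2ccncc2)cc1-c1cccc(C(=O)OCC2CCCCC2)c1`: 48 nM

Both compounds were tested in an assay on isolated protein for inhibition of Rho-associated protein kinase 2 (Homo sapiens), read by radiometric assay; a lower number here means a stronger inhibitor, a higher number a weaker inhibitor. Compound 1 shows the lower of the two numbers, and compound 2 lies well beyond the usual scatter of it, so the gap is a real one. The two structures differ in more than one place, so the gap cannot be tied to any single change; it only shows that a saturated ring on the ester, together with the missing fluorine, goes with a weaker inhibitor in this assay.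

Compound 3, `NCc1ccc(C(=O)Nc2ccncc2F)cc1-c1cccc(C(=O)OC2CCCOC2)c1`, has not yet been tested. It differs from compound 1 in one place: oxan-3-yl in place of phenyl on an oxygen next to a carbonyl group. The fluorine of compound 1 is kept.

Among the compounds with values here, no measured pair isolates this exact change. The step of a 3.2-fold higher number from compound 1 to compound 3 (0.51 log units; beyond the scatter) is expected to be a modest rise, guided by compound 2 and its value of 48 nM, but smaller than that gap since only the ester changes here. Compound 3 is therefore estimated at 20 nM, with a range from 6 nM to 70 nM.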

Compound 3, half-maximal inhibitory concentration: 8.7 nM
Estimate against measurement, compound 3: 2.3-fold (0.36 log units) above, within the range that was stated.
By their numbers in this assay, from the lowest: compounds 1 and 3 (each within the scatter of the next); then compound 2.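

Putting oxan-3-yl in place of phenyl on an oxygen next to a carbonyl group gives a 1.4-fold higher number from compound 1 to compound 3 (0.15 log units; within the scatter) in this assay, so the two compounds cannot be told apart in this test. For this pair, then, an aromatic ring of carbon only and a non-aromatic six-membered ring with one hetero atom serve equally well at this position, even though the swap keeps the count of heavy atoms and adds one hydrogen-bond acceptor. Nothing measured here explains why the number stays within the scatter.

Going by these compounds, all three compounds carry the ester, so it remains open whether the ester link itself matters, and a carboxylic acid or an amide in its place would test that directly. It also remains open what the fluorine contributes, or how a simple methyl or a longer chain on the same oxygen would compare, since no two compounds shown differ in the fluorine alone.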